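Shortening the Alkylamine Chain on a Biaryl Core

The source may report more compounds than this note shows. Statements on the series, on what has been measured and on what is new or still open speak of the compounds shown alone.

Compound 1 `COc1ccccc1-c1cc(C2CCNC2)ccc1Cl`: 770 nM
Compound 2 `CNCc1ccc(Cl)c(-c2ccccc2OC)c1`: 2400 nM
Compound 3 `CCCCNCc1ccc(Cl)c(-c2ccccc2OC)c1`: > 10000 nM

These numbers come from an assay on isolated protein for binding affinity to 5-hydroxytryptamine receptor 1E (Homo sapiens); a lower number here means a stronger inhibitor, a higher number a weaker inhibitor. Compound 3 sits at a limit of the assay, (the limit of > 10000 nM in this assay, at which 1 of the 3 values shown sits), so its value is not a number, and it is the weakest of the three. Compound 4 `CCCNCc1ccc(Cl)c(-c2ccccc2OC)c1` differs from compound 3 by hydrogen in place of methyl on a saturated chain carbon, three bonds along the chain from an amine nitrogen. The step that bears on this is an at least 4.1-fold higher number from compound 2 to compound 3 (0.61 log units; beyond the scatter), the same chain change cut one bond further out; the larger step of an at least 12-fold higher number from compound 1 to compound 3 (1.11 log units; beyond the scatter) also ends at compound 3. Removing one carbon is therefore expected to lower the number, though from a limit the size cannot be fixed. Compound 4 is estimated at 6000 nM, within 2500 nM to 20000 nM, a step of an at least 1.6-fold lower number from compound 3 to compound 4 (0.22 log units; that floor lies within the scatter).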

Compound 4, inhibition constant: > 10000 nM
Compound 4 gave a limit, no number (the forecaster's own chance of this, stated with the estimate: 35%); at least 1.6-fold (0.22 log units) between middle value and limit.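

In this assay compound 4 gives > 10000 nM, a limit and not a number. The step between compound 3 and compound 4 cannot be read, because both stand at the same limit: the limit of > 10000 nM in this assay, at which 2 of the 4 values shown sit. Shortening butyl to propyl therefore brings no readable return towards the stronger compounds, with an at least 4.1-fold higher number from compound 2 to compound 4 (0.61 log units; beyond the scatter) and an at least 12-fold higher number from compound 1 to compound 4 (1.11 log units; beyond the scatter).

The compounds shown leave open how (ethylamino)methyl would stand in this assay, and so at which chain length the number reaches the limit. They also leave open how a branched isopropyl group on the amine would compare.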